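Swapping a Benzylsulfanyl Arm for Pyrazole on a Nucleoside

The compounds below may be only part of what the source reports. "The series", "measured", "known", "first", "only" and "open" are said of these compounds alone.

Compound 1 `OC[C@H]1O[C@@H](n2cnc3c(CSCc4ccccc4)ncnc32)[C@H](O)[C@@H]1O` was examined in a functional assay on Huh-7 cells (Homo sapiens) for cytotoxicity, read by MTT assay, with a stated time of 3 days; on this read-out lower numbers stand for higher toxicity in this test and higher numbers for lower toxicity in this test. In this assay compound 1 gives > 100000 nM, which is a limit of the assay and not a measured number. Compound 2 `CC(=O)N(Cc1ncnc2c1ncn2[C@@H]1O[C@H](CO)[C@@H](O)[C@H]1O)C1CCCCC1` carries a different arm on the shared core. In this assay compound 2 gives > 100000 nM, again a limit rather than a number. Both results thus sit at the same boundary (the limit of > 100000 nM in this assay, at which 2 of the 2 values shown sit), so compound 1 stands at the limit together with compound 2 and no order between the two can be read.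

Compound 3 `OC[C@H]1O[C@@H](n2cnc3c(Cn4cccn4)ncnc32)[C@H](O)[C@@H]1O` has not yet been measured. It differs from compound 1 in one place: 1H-pyrazol-1-yl in place of benzylsulfanyl on a saturated chain carbon bound to an aromatic carbon. Within the data shown here, no step between two measured compounds with real numbers exists, so there is nothing that would point in either direction. Compound 1 gives only the limit > 100000 nM in this assay. The step that the limit leaves unreadable from compound 1 to compound 3 is therefore expected to be none beyond the scatter. Compound 3 is estimated at 150000 nM, with a range from 50000 nM to 500000 nM, and the assay is expected most likely to report only a limit once more.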

Compound 3, half-maximal cytotoxic concentration: > 250000 nM
Compound 3: a limit, no number; the forecaster's own chance of this, stated with the estimate: 80%; middle value at least 1.6-fold (0.22 log units) from the limit.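

In this assay compound 3 gives > 250000 nM, which is a limit of the assay and not a number. Among these compounds, compound 1 also gives only a limit, so no step between compound 1 and compound 3 can be read. The compounds shown leave open whether 1H-pyrazol-1-yl in place of benzylsulfanyl changes toxicity to these cells at all.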